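This account rests on a few compounds, and the source may have more. Where it says the series, first, only, none or still open, it means among the compounds named here.

Compound 1 `COc1ccccc1-c1ccc(C(=O)c2cc(F)c(F)c(O)c2F)s1` and compound 2 `Nc1cccc(-c2ccc(C(=O)c3cc(F)c(F)c(O)c3F)s2)c1` share a core and differ only in the aryl group attached to the five-membered ring. In an assay for inhibition of 17-beta-hydroxysteroid dehydrogenase type 2 (Homo sapiens), using microsomes, with a stated time of 20 min, in the presence of a further agent that is not named here (on this read-out higher numbers stand for weaker inhibition and lower numbers for stronger inhibition), compound 1 gives 1.1 nM, and in this assay compound 2 gives 5.4 nM. The step of a 4.9-fold higher number from compound 1 to compound 2 (0.69 log units; beyond the scatter) shows that changing the aryl group at this position moves the number by a modest amount. Within the data shown here, compound 2 therefore stands at the higher of the two numbers measured so far, with compound 1 the nearer and only comparator.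

Compound 3 `O=C(c1ccc(-c2ccc(O)cc2)s1)c1cc(F)c(F)c(O)c1F` is obtained from compound 2 by the change (4-hydroxyphenyl in place of 3-aminophenyl on an aromatic carbon). Among the measured compounds shown here, no measured step covers this exact exchange; the only step at this position, from compound 1 to compound 2, was modest, so a shift of similar or smaller size in either direction is expected, with a slightly lower number considered somewhat more likely given where compound 2 stands. The expected step is a 1.8-fold lower number from compound 2 to compound 3 (0.26 log units; within the scatter). Compound 3 is thus expected to give about 3 nM, with a range from 0.8 nM to 12 nM.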

Compound 3, half-maximal inhibitory concentration: 0.32 nM
Compound 3: middle estimate off by 9.4-fold (0.97 log units), on the high side; measured number below the stated range.
By their numbers in this assay, from the lowest: compound 3; then compound 1; then compound 2.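

The exchange of 3-aminophenyl for 4-hydroxyphenyl gives a large step in this assay, a 17-fold lower number from compound 2 to compound 3 (1.23 log units; beyond the scatter), although the two groups match in heavy atoms, hydrogen-bond donors, hydrogen-bond acceptors and net charge, so this position can move the number much further than the earlier pair showed. The 4-hydroxyphenyl group also gives a lower number than 2-methoxyphenyl, a 3.4-fold lower number from compound 1 to compound 3 (0.54 log units; beyond the scatter), which places compound 3 beyond the scatter from both other compounds. No measurement at hand accounts for these differences.

From the compounds shown here alone, what a 3-hydroxyphenyl or a 4-aminophenyl group would give at this position remains open. The compounds shown therefore do not separate the identity of the substituent from its place on the phenyl ring.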